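This account rests on a few compounds, and the source may have more. Where it says the series, first, only, none or still open, it means among the compounds named here.

Within the data shown here, in a toxicity assay on HeLa cells (Homo sapiens) for cytotoxicity, read by CCK-8 assay, with stated times of 16 h and 24 h (a higher number here means a weaker inhibitor, a lower number a stronger inhibitor), compound 1 `COc1ccc2c(c1)CCc1c(-c3ccccc3)c3n(c1-2)[B-](F)(F)[N+]1=C(c2ccc(OCC(=O)O)cc2)C(I)=C(c2ccccc2)C1=N3` gives 274 nM and compound 2 `COc1ccc2c(c1)CCc1c(-c3ccccc3)c3n(c1-2)[B-](F)(F)[N+]1=C(c2ccc(OCC(=O)N[C@@H](CC(=O)O)C(=O)O)cc2)C(I)=C(c2ccccc2)C1=N3` gives 55 nM, the lower of the two numbers so far. Compound 3 `COc1ccc2c(c1)CCc1c(-c3ccccc3)c3n(c1-2)[B-](F)(F)[N+]1=C(c2ccc(OCC(=O)N[C@@H](CCC(=O)O)C(=O)O)cc2)C(I)=C(c2ccccc2)C1=N3` differs from compound 2 by carboxymethyl in place of carboxy on a saturated chain carbon, two bonds along the chain from an amide-type nitrogen and a carbonyl carbon, with carboxymethyl in place of carboxy on a saturated chain carbon. Among the measured compounds shown here, the only measured step that bears on this, a 5.0-fold lower number from compound 1 to compound 2 (0.70 log units; beyond the scatter), brought in the whole (1,2-dicarboxyethyl)amino group and sets no size for this smaller change. No step beyond the scatter is therefore expected in this assay. The expected step is a 1.2-fold higher number from compound 2 to compound 3 (0.07 log units; within the scatter). Compound 3 is estimated at 65 nM, with an expected range of 28 nM to 150 nM.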

Compound 3, half-maximal inhibitory concentration: 119 nM
Compound 3: middle estimate off by 1.8-fold (0.26 log units), on the low side; the range from low to high includes it.
By their numbers in this assay, from the lowest: compound 2; then compound 3; then compound 1.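

In this assay, carboxymethyl in place of carboxy on this saturated chain carbon is not a silent change: the series shows a 2.2-fold higher number from compound 2 to compound 3 (0.34 log units; beyond the scatter) and so responds to the extra carbon in this side chain. Against the hydroxy of compound 1, the (1,3-dicarboxypropyl)amino group still gives a 2.3-fold lower number from compound 1 to compound 3 (0.36 log units; beyond the scatter) in this assay as a retained gain. Nothing available explains this shift. Still open, going by these compounds, is whether a longer chain ending in a carboxylic acid would raise the number further, and whether an amine in place of that acid would keep the gain.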